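This account rests on a few compounds, and the source may have more. Where it says the series, first, only, none or still open, it means among the compounds named here.

In a functional assay on K562 cells (Homo sapiens) for inhibition, read by sulforhodamine B assay, with a stated time of 48 h (a higher number here means a weaker inhibitor of growth, a lower number a stronger inhibitor of growth), compound 2 `Nc1nn(C(=O)Nc2ccc(Cc3ccccc3)cc2)c2ccccc12` gives 1200 nM, the lowest of the two numbers recorded in this series. Compound 1 `O=C(Nc1ccc(Cc2ccccc2)cc1)Nc1nn(C(=O)Nc2ccc(Cc3ccccc3)cc2)c2ccccc12` gives 40500 nM in this assay, a gap from compound 2 that lies well beyond the scatter of repeated measurements. Going by the values given here, compound 3 `COc1ccc(NC(=O)Nc2n[nH]c3ccccc23)cc1` reaches only a limit of this assay, > 100000 nM, and no number is known for it; this is the one value that sits at the limit of > 100000 nM in this assay, at which 1 of the 3 values shown sits.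

Compound 4 `CCCCOc1ccc(NC(=O)n2nc(N)c3ccccc32)cc1` has not yet been measured in this assay. It differs from compound 2 in one place: butoxy in place of benzyl on an aromatic carbon, para to a large group. Among the compounds with values here, no pair of measured compounds shows this exact change, so the size of the step can only be expected, not read off. The account expects a modest rise in the number, a little beyond the scatter rather than a large shift, with the direction toward weaker inhibition of growth.

Compound 4 is therefore expected to give about 3000 nM in this assay, within a range from 800 nM to 12000 nM, which corresponds to an estimated step of a 2.5-fold higher number from compound 2 to compound 4 (0.40 log units; beyond the scatter).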

Compound 4, concentration for 50% growth inhibition: 15900 nM
Estimate against measurement, compound 4: 5.3-fold (0.72 log units) below, outside the stated range (above it).
By their numbers in this assay, from the lowest: compound 2; then compound 4; then compound 1. At a limit, above all of these: compound 3.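

Going by these compounds alone, this is the first step read at this place, on an aromatic carbon para to a large group, and in this assay it is a large one: putting butoxy in place of benzyl gives (a 13-fold higher number from compound 2 to compound 4 (1.12 log units; beyond the scatter)). The position therefore does not accept any group of similar length equally, since an open chain ending in no ring, carrying an oxygen on the aromatic carbon, gives a clearly weaker inhibitor of growth than benzyl does on the same core. Nothing measured for these compounds bears on why the step is this large.

The step removes the six-membered aromatic ring and brings in the oxygen at once, so it remains open which of the two accounts for the change; a phenoxy group, which keeps both the ring and an oxygen, or a pentyl chain, which has neither, at this same place would separate them. From the compounds shown here alone, it also remains open how the number moves with chain length on the oxygen, from methoxy up to a longer chain such as hexyloxy, or with an amine or a carboxylic acid at the end of the chain.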